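Methyl for Fluoro on the Benzyl Ring of Compound 2

The source may hold more compounds than are shown below. What is called first, only, known or untested is meant among the compounds shown, and "the series" means these compounds.

Within the data shown here, compound 2 `COc1ccc(N2C(=O)N(Cc3c(F)cc(F)cc3Cl)c3ccccc3S2(=O)=O)cc1OC` gives 25.1 nM in an assay on isolated protein for displacement of a labelled ligand from Orexin/Hypocretin receptor type 1 (Homo sapiens), with a stated time of 90 min (a lower number here means a stronger inhibitor, a higher number a weaker inhibitor), the lowest of the two numbers measured so far; compound 1 `COc1ccc(N2C(=O)N(Cc3ccccc3F)c3ccccc3S2(=O)=O)cc1OC` gives 316 nM in this assay. Compound 3 `COc1ccc(N2C(=O)N(Cc3c(F)cc(C)cc3Cl)c3ccccc3S2(=O)=O)cc1OC` differs from compound 2 by methyl in place of fluoro on an aromatic carbon. Among the measured compounds shown here, the only measured step also altered this benzyl ring, a 13-fold lower number from compound 1 to compound 2 (1.10 log units; beyond the scatter), but it added and exchanged halogens rather than making one substitution, so it bears only loosely on the present change. A step of a 1.2-fold higher number from compound 2 to compound 3 (0.08 log units; within the scatter) is therefore expected, not beyond the scatter. For compound 3 the estimate is 30 nM, within 10 nM to 100 nM.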

Compound 3, inhibition constant: 6.31 nM
The estimate for compound 3 lay 4.8-fold (0.68 log units) above the measured number, outside the stated range (below it).
By their numbers in this assay, from the lowest: compound 3; then compound 2; then compound 1.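

In this assay, the ring carbon para to a large group proves sensitive to a one-atom exchange, with methyl in place of fluoro giving a 4.0-fold lower number from compound 2 to compound 3 (0.60 log units; beyond the scatter). Fluoro is therefore not needed at this carbon, and the full change to the benzyl group now amounts to a 50-fold lower number from compound 1 to compound 3 (1.70 log units; beyond the scatter). No measurement available here explains why methyl outperforms fluoro at this carbon.

As far as these compounds go, whether an ethyl, a methoxy or an amine at this carbon would match methyl remains open. So does whether methyl would have the same effect without the chloro group on the ring.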